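The source may report more compounds than this note shows. Statements on the series, on what has been measured and on what is new or still open speak of the compounds shown alone.

Measured compounds:
compound 1, `CC(=O)/C=C/c1ccc(OC2CCCC2)cc1`: 21800 nM
compound 2, `O=C1CCCCC/C1=C\c1ccc(OC2CCCC2)cc1`: 26900 nM

In a functional assay on PC-3 cells (Homo sapiens) for antiproliferative activity, read by MTT assay (a higher number here means a weaker inhibitor, a lower number a stronger inhibitor), compound 1 gives 21800 nM, and compound 2 gives 26900 nM; the gap between the two lies within the scatter of repeated measurements, so neither can be set apart from the other. Compound 3, `Cc1ccc(C(=O)/C=C/c2ccc(OC3CCCC3)cc2)cc1`, differs from compound 1 by 4-methylphenyl in place of methyl on a carbonyl carbon. For the measured compounds named here, no step of this kind has been measured, so the expectation rests only on compound 1 and its value of 21800 nM. Compound 3 is expected to give a modestly lower number, a step of a 2.2-fold lower number from compound 1 to compound 3 (0.34 log units; beyond the scatter), somewhat beyond the scatter. The estimate for compound 3 is 10000 nM, within the range 3000 nM to 30000 nM.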

Compound 3, half-maximal inhibitory concentration: 17100 nM
Beside the measured number, compound 3's estimate is 1.7-fold (0.23 log units) below it; measured number inside the range.
By their numbers in this assay, from the lowest: compounds 3, 1 and 2 (each within the scatter of the next).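

In this assay, the change from methyl to 4-methylphenyl on a carbonyl carbon comes to a 1.3-fold lower number from compound 1 to compound 3 (0.11 log units; within the scatter), so a six-membered aromatic ring of carbon only can stand at this position with no change that can be told apart from the scatter. Nothing available gives a reason for this result. Left open is how a phenyl ring carrying an amine or a carboxylic acid, or a longer chain, would fare on this carbonyl carbon. Also open, from the compounds shown here alone, is whether any group here can move the number beyond the scatter.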